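Ethoxy in place of methoxy on the acetate analogue

This account rests on a few compounds, and the source may have more. Where it says the series, first, only, none or still open, it means among the compounds named here.

Measured so far in a functional assay on KB cells (Homo sapiens) for cytotoxicity, read by MTT assay, with a stated time of 72 h; on this read-out lower numbers stand for an effect already at smaller amounts and higher numbers for an effect only at larger amounts of compound:
Compound 1 `CCOc1c(-c2occ(C)c2C(=O)O)ccc2c(CC)cccc12` gives > 10 ug/mL, a limit of this assay.
Compound 2 `CCOc1c(-c2occ(C)c2C(=O)OC)ccc2c(CC)cccc12` gives 1.8 ug/mL.
Compound 3 `CCc1cccc2c(OC)c(-c3occ(C)c3COC(C)=O)ccc12` gives > 10 ug/mL, a limit of this assay.

Compound 3 therefore stands at the upper limit of this assay and carries no number; it shares this with compound 1 (the limit of > 10 ug/mL in this assay, at which 2 of the 3 values shown sit), while compound 2 alone gives a value. Compound 4 `CCOc1c(-c2occ(C)c2COC(C)=O)ccc2c(CC)cccc12` differs from compound 3 by methyl in place of hydrogen on a saturated chain carbon bound to an oxygen on an aromatic ring, in other words methoxy to ethoxy on the shared core.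

For the measured compounds named here, the only measured step, an at least 5.5-fold lower number from compound 1 to compound 2 (0.74 log units; beyond the scatter), concerns the carboxylic acid versus its methyl ester and does not touch the group changed here. Going by the values given here, no measured pair isolates the methoxy-to-ethoxy change; compound 1 and compound 2 already carry the ethoxy group, and compound 3 carries the methoxy with the acetate chain. No basis is thus at hand for a step beyond the scatter in this assay.

Compound 4 is expected at 12 ug/mL (range 4 ug/mL to 40 ug/mL), most likely again reported only as a limit. The expected step that the limit leaves unreadable from compound 3 to compound 4 is estimated as none beyond the scatter.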

Compound 4, concentration for half-maximal effect: > 10 ug/mL
Compound 4: only a limit was reported (the forecaster's own chance of this, stated with the estimate: 70%); the middle value is on the limit's open side.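

Compound 4 gives > 10 ug/mL in this assay, which is a limit and not a number. For the compounds shown here, with ethoxy held constant, an at least 5.5-fold higher number from compound 2 to compound 4 (0.74 log units; beyond the scatter) comes with acetoxymethyl in place of methoxycarbonyl on an aromatic carbon, so ethoxy alone does not bring a readable value, and the methyl ester compound 2 remains the only compound here that has one. The steps from compound 3 and from compound 1 to compound 4 cannot be read, and the series now sits mostly at one limit: the limit of > 10 ug/mL in this assay, at which 3 of the 4 values shown sit.

Open, from the compounds shown here alone, is what methoxy to ethoxy does on a compound that gives a number, as the acetate pair cannot tell. Also open, going by these compounds, is how an amide or a hydroxymethyl group in place of the methoxycarbonyl would read, or a longer chain in place of the ethoxy.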